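A few compounds are considered here, and "the series" means these few. Any claim that something is new, unique, unknown or untested is made for them only; others in the source may bear on it.

Of the compounds shown here, two of a shared core have been measured in a functional assay on Huh-7 cells (Homo sapiens) for inhibition, read by MTT assay, with a stated time of 48 h; on this read-out lower numbers stand for stronger inhibition and higher numbers for weaker inhibition. Compound 1 `COc1ccc2c(=O)c(/C=C/C(=O)Nc3cccc(Cl)c3)coc2c1` carries a 3-chlorophenyl group on its amide-type nitrogen. In this assay compound 1 gives only a limit, > 100000 nM, and not a number. Compound 2 `COc1ccc2c(=O)c(/C=C/C(=O)Nc3ccc(Cl)cc3)coc2c1` carries a 4-chlorophenyl group instead, and in this assay compound 2 gives 37100 nM. That change reads as an at least 2.6-fold lower number from compound 1 to compound 2 (0.43 log units; beyond the scatter). Compound 2 therefore holds the only number shown. The remaining value, that of compound 1, is the limit of > 100000 nM in this assay, at which 1 of the 2 values shown sits.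

Compound 3 `COc1ccc2c(=O)c(/C=C/C(=O)Nc3ccc(F)cc3)coc2c1` is not yet measured. It differs from compound 2 in one place: fluoro in place of chloro on an aromatic carbon. Going by the values given here, no measured step exchanges one halogen for another; the single measured step only shifts a chloro group from 3-chlorophenyl to 4-chlorophenyl, so it does not bear directly on this change. With nothing in the data pointing either way, the step from compound 2 to compound 3 is expected to stay within the scatter, as a 1.3-fold higher number from compound 2 to compound 3 (0.13 log units; within the scatter). Compound 3 is accordingly estimated at 50000 nM, with a range from 15000 nM to 150000 nM.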

Compound 3, half-maximal inhibitory concentration: 33900 nM
The estimate for compound 3 lay 1.5-fold (0.17 log units) above the measured number; the measured number falls inside the stated range.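

In this assay, fluoro in place of chloro on an aromatic carbon, para to a large group, reads as a 1.1-fold lower number from compound 2 to compound 3 (0.04 log units; within the scatter), so the two values cannot be told apart. The earlier step only moved a chloro group, from 3-chlorophenyl to 4-chlorophenyl, whereas this one keeps the place and exchanges the halogen, and for these two halogens the identity of the atom makes no visible difference to the read-out. Going by these compounds alone, the 4-fluorophenyl group also stands apart from the 3-chlorophenyl group, as an at least 2.9-fold lower number from compound 1 to compound 3 (0.46 log units; beyond the scatter), so both compounds with a halogen in this place have a number, while the one compound with its chloro group elsewhere does not.

On these data alone, the true size of those steps from compound 1 stays open, because compound 1 gives a limit and not a number: the limit of > 100000 nM in this assay, at which 1 of the 3 values shown sits. Also open, as far as these compounds go, is what a group other than a halogen would do in this place, such as an amine, a carboxylic acid or a methoxy group, and whether a phenyl ring with no group on it would read any differently.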